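Working notes: amide-side aryl swap in a cytotoxicity series

A few compounds are considered here, and "the series" means these few. Any claim that something is new, unique, unknown or untested is made for them only; others in the source may bear on it.

Measured so far:
compound 1 `COc1ccc(C(=O)c2cc(OC)c(OC)c(OC)c2)cc1N` — 1100 nM
compound 2 `COc1cccc(/C=C/C(=O)Nc2cc(C(=O)c3cc(OC)c(OC)c(OC)c3)ccc2OC)c1` — 4700 nM

In a functional assay on PC-3 cells (Homo sapiens) for cytotoxicity, read by MTT assay, with a stated time of 72 h (a higher number here means a weaker inhibitor, a lower number a stronger inhibitor), compound 2 holds the higher of the two numbers; its nearest neighbour is compound 1, and that gap is beyond the scatter. Compound 3 `COc1ccc(C(=O)c2cc(OC)c(OC)c(OC)c2)cc1NC(=O)/C=C/c1ccc(F)cc1` differs from compound 2 by 4-fluorophenyl in place of 3-methoxyphenyl on a double-bonded chain carbon bound to a double-bonded chain carbon. Among the measured compounds shown here, no measured pair isolates this change, so no step is known for it. The expected step in this assay is small, none beyond the scatter, with no clear direction. Compound 3 is therefore estimated at 4000 nM, within 1500 nM to 11000 nM. The expected step is a 1.2-fold lower number from compound 2 to compound 3 (0.07 log units; within the scatter).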

Compound 3, half-maximal inhibitory concentration: 3200 nM
Compound 3: the middle estimate sits 1.3-fold (0.10 log units) above what was measured, and the stated range covers the measured number.
By their numbers in this assay, from the lowest: compound 1; then compounds 3 and 2 (each within the scatter of the next).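

In this assay, 4-fluorophenyl in place of 3-methoxyphenyl on the double-bonded chain carbon gives a 1.5-fold lower number from compound 2 to compound 3 (0.17 log units; within the scatter), so this exchange of aryl groups does not separate the two amides. Adding the (2-(4-fluorophenyl)ethenyl)carbonyl group in place of hydrogen on the nitrogen gives a 2.9-fold higher number from compound 1 to compound 3 (0.46 log units; beyond the scatter), a modest step that gives the first direct reading of acylation at this nitrogen. No supporting data bear on the reason for either step.

As far as these compounds go, whether an amine or a carboxylic acid on this aryl ring would give a step beyond the scatter remains open, as does the effect of a longer chain in place of the ethenyl link.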